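Cytotoxicity of thiazolylidene hydrazides in mouse fibroblasts

The source may hold more compounds than are shown below. What is called first, only, known or untested is meant among the compounds shown, and "the series" means these compounds.

The measured compounds and their values:
compound 1 `Cc1nnc(SCC(=O)N/N=c2/scc(-c3ccccc3)n2-c2ccccc2)s1` gives 197 ug/mL
compound 2 `O=C(CSc1ncccn1)N/N=c1/scc(-c2ccccc2)n1-c1ccccc1` gives 107 ug/mL
compound 3 `O=C(CSc1nnnn1-c1ccccc1)N/N=c1/scc(-c2ccccc2)n1-c1ccccc1` gives 417 ug/mL

The three compounds share a core and differ only in the heteroaryl group on the sulfur. They were tested in an ADME assay on NIH3T3 cells (Mus musculus) for cytotoxicity, read by MTT assay, with a stated time of 24 h; a higher number here means a weaker inhibitor, a lower number a stronger inhibitor. Compound 1 stands second highest of the three numbers; compound 2 lies nearest, with a 1.8-fold lower number from compound 1 to compound 2 (0.27 log units; within the scatter), a step within the scatter, while compound 3 lies furthest, with a 2.1-fold higher number from compound 1 to compound 3 (0.33 log units; beyond the scatter). Between the other two, a 3.9-fold higher number from compound 2 to compound 3 (0.59 log units; beyond the scatter).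

Compound 4 `Cc1ccc(-c2cs/c(=N/NC(=O)CSc3nnc(C)s3)n2-c2ccccc2)cc1` keeps the heteroaryl group of compound 1 and alters the core instead: methyl in place of hydrogen on an aromatic carbon. Within the data shown here, none of the measured steps touches this position; all three swap the group on the sulfur and leave the phenyl ring untouched. Among the measured compounds shown here, there is therefore no step in hand that bears on the change from compound 1 to compound 4, and the expected step in this assay is none beyond the scatter, that is, a 1.0-fold higher number from compound 1 to compound 4 (0.01 log units; within the scatter).

For compound 4 the estimate in this assay is 200 ug/mL, with a range from 100 ug/mL to 400 ug/mL.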

Compound 4, half-maximal inhibitory concentration: 373 ug/mL
The estimate for compound 4 lay 1.9-fold (0.27 log units) below the measured number, and the stated range covers the measured number.
By their numbers in this assay, from the lowest: compounds 2, 1, 4 and 3 (each within the scatter of the next, the first and the last beyond it).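

In this assay, the change from phenyl to 4-methylphenyl is the only step shown that leaves the group on the sulfur alone, and it gives a 1.9-fold higher number from compound 1 to compound 4 (0.28 log units; within the scatter). The earlier steps shown here all swapped the group on the sulfur and so said nothing about this aromatic carbon, para to a large group; this step shows that a methyl can enter here without moving the number beyond the scatter, although it cannot separate a small real shift from repeat-to-repeat variation. Nothing available explains the size of this step, so the reading stays at the level of the numbers.

The compounds shown leave open whether a group other than methyl at the same place, such as an amine, a carboxylic acid or a longer chain, would also stay within the scatter. Among these compounds, they also leave open whether the methyl would give a similar step with pyrimidin-2-yl or 1-phenyl-1H-tetrazol-5-yl on the sulfur, since it has been seen only with 5-methyl-1,3,4-thiadiazol-2-yl there.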